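Cyclopropyl for methyl on the pyridine of compound 3

The source may hold more compounds than are shown below. What is called first, only, known or untested is meant among the compounds shown, and "the series" means these compounds.

Of the compounds shown here, three have been measured in an assay on T-REx-293 cells for inhibition of potassium channel subfamily T member 1 (Homo sapiens), read by patch clamp; a lower number here means a stronger inhibitor, a higher number a weaker inhibitor. Compound 1 `Cc1cccc(-c2noc([C@H](C)NC(=O)c3cc(C4CC4)n(C)n3)n2)c1` reaches only a limit of the assay, > 30000 nM; (the limit of > 30000 nM in this assay, at which 1 of the 3 values shown sits). Compound 2 `Cc1cccc(-n2cc(C(C)NC(=O)c3cc(C(F)(F)F)nn3C)cn2)c1` gives 1600 nM in this assay. Compound 3 `Cc1cc(-c2noc([C@H](C)NC(=O)c3cc(C(F)(F)F)nn3C)n2)ccn1` gives 165 nM and so holds the lowest of the two numbers shown, with compound 2 at a value higher by an amount beyond the usual scatter of this assay.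

Compound 4 `C[C@H](NC(=O)c1cc(C(F)(F)F)nn1C)c1nc(-c2ccnc(C3CC3)c2)no1` has not been measured. It differs from compound 3 in one place: cyclopropyl in place of methyl on an aromatic carbon, that is, 2-methylpyridin-4-yl becomes 2-cyclopropylpyridin-4-yl. Within the data shown here, no measured pair shows such an exchange, so no direction can be taken from the data. The step from compound 3 to compound 4 is expected to be small in this assay, a 1.4-fold lower number from compound 3 to compound 4 (0.14 log units; within the scatter), either way within or barely beyond the usual scatter. Compound 4 is estimated at 120 nM, with a range from 40 nM to 400 nM.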

Compound 4, half-maximal inhibitory concentration in the potassium channel subfamily T member 1 assay: 16 nM
Beside the measured number, compound 4's estimate is 7.5-fold (0.88 log units) above it; measured number outside the range, below it.
By their numbers in the potassium channel subfamily T member 1 assay, from the lowest: compound 4; then compound 3; then compound 2. At a limit, above all of these: compound 1.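

Methyl is not the limit at this position, on an aromatic carbon next to the ring nitrogen: in the potassium channel subfamily T member 1 assay, cyclopropyl in its place gives a 10-fold lower number from compound 3 to compound 4 (1.01 log units; beyond the scatter). Among these compounds, no earlier pair changed anything here, so this is the first evidence that the series responds strongly to the group at this place. The same exchange also lowers solubility, as measured in a physicochemical assay for solubility, measured as kinetic solubility; on this read-out lower numbers stand for lower solubility and higher numbers for higher solubility: the measured solubility of compound 3, 179000 nM, and of compound 4, 16000 nM, an 11-fold lower number (1.05 log units; beyond the scatter) In the physicochemical assay compound 3 gives 179000 nM and compound 4 gives 16000 nM on that read-out.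

With only methyl and cyclopropyl shown at this position, a single step cannot separate the size of the group from anything particular to the three-membered ring, and isopropyl or cyclobutyl would test that reading. On these data alone, whether the two effects can be parted also stays open, for instance with a methoxy group or an amine at the same carbon.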